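This account rests on a few compounds, and the source may have more. Where it says the series, first, only, none or still open, it means among the compounds named here.

In a functional assay on the whole organism (strain Wistar) for inhibition, with Rattus norvegicus as the target, read by paw edema, with a stated time of 1 h, at a dose of 100 mg/kg (a lower number here means less inhibition, a higher number more inhibition at the dose given (going by the name of the read-out)), the three measured compounds stand as follows:
compound 1 `COc1cc2c(cc1OC)C(CC(=O)Nc1ccc(Br)cc1)CC2` gives 50%;
compound 2 `COc1cc2c(cc1OC)C(CC(=O)Nc1cccc(C)c1)CC2` gives 37.5%;
compound 3 `COc1cc2c(cc1OC)C(CC(=O)Nc1ccc(C)cc1)CC2` gives 34.4%.

Compound 3 holds the lowest of the three numbers in this assay: compound 2 is nearest to it, within the scatter, and compound 1 is furthest, beyond it. Compound 4 `COc1cc2c(cc1OC)C(CC(=O)Nc1cccnc1)CC2` differs from compound 3 in one place: pyridin-3-yl in place of 4-methylphenyl on an amide-type nitrogen. Among the compounds with values here, none of the measured steps exchanges a ring of carbon only for a ring with a hetero atom, so no step bears directly on this change. The steps that are known concern other groups: a number 12.5 percentage points lower from compound 1 to compound 2 (beyond the scatter) and a number 15.6 percentage points lower from compound 1 to compound 3 (beyond the scatter), both modest, whereas a number 3.1 percentage points lower from compound 2 to compound 3 (within the scatter). Within the data shown here, they show only that the two methylphenyl groups sit within the scatter of each other and say nothing about a ring nitrogen. Compound 4 is therefore expected to show a number 0.6 percentage points higher from compound 3 to compound 4 (within the scatter), with a wide range around it. Compound 4 is estimated to give 35%, between 20% and 50%.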

Compound 4, a percentage reported as inhibition, in the whole organism at one dose (the size of the read-out at that dose, not a potency): 25%
For compound 4 the middle estimate is 10 percentage points above the measured one; low and high end bracket the measured number.
By their numbers in this assay, from the lowest: compounds 4, 3 and 2 (each within the scatter of the next, the first and the last beyond it); then compound 1.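

With compound 4, a ring with a hetero atom stands on the amide-type nitrogen for the first time among these compounds, and in this assay the exchange of 4-methylphenyl for pyridin-3-yl gives a number 9.4 percentage points lower from compound 3 to compound 4 (within the scatter) and so does not set these two groups apart. Against the other rings, pyridin-3-yl does stand apart, with a number 12.5 percentage points lower from compound 2 to compound 4 (beyond the scatter) and with a number 25 percentage points lower from compound 1 to compound 4 (beyond the scatter) as the widest gap seen at this place. Nothing available gives a reason for these differences.

What the compounds shown leave open is whether the ring at this place is needed at all, as a cyclohexyl group or a plain ethyl chain would test. They also leave open how a chlorophenyl, a pyrimidinyl or a carboxylic acid on the ring would compare.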